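A hydroxylated chain replaces a pyridine-bearing group

The source may report more compounds than this note shows. Statements on the series, on what has been measured and on what is new or still open speak of the compounds shown alone.

Of the compounds shown here, three sharing one core have been measured in an ADME assay on A549 cells (Homo sapiens) for cytotoxicity, read by resazurin assay, with a stated time of 48 h; on this read-out lower numbers stand for higher toxicity in this test and higher numbers for lower toxicity in this test. Compound 1 `O=C(Nc1ccc(NCC2CC2)cc1Cl)c1cc(Cl)ccc1O` gives 14400 nM, compound 2 `O=C(Nc1ccc(NC2CCCCC2)cc1Cl)c1cc(Cl)ccc1O` gives 68300 nM, and compound 3 `O=C(Nc1ccc(NCc2cnccc2Cl)cc1Cl)c1cc(Cl)ccc1O` gives 126000 nM. Compound 3 has the largest of these numbers, but that lead is not firm against both neighbours: there is a 1.8-fold higher number from compound 2 to compound 3 (0.27 log units; within the scatter), while there is also an 8.8-fold higher number from compound 1 to compound 3 (0.94 log units; beyond the scatter).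

Compound 4 `CC(CCO)Nc1ccc(NC(=O)c2cc(Cl)ccc2O)c(Cl)c1` carries 3-hydroxy-1-methylpropyl in place of (4-chloropyridin-3-yl)methyl on a nitrogen on an aromatic ring. Among the measured compounds shown here, no measured step makes this exact change. The nearest guides are the two steps that link the same group to the cyclopropylmethyl of compound 1 and the cyclohexyl of compound 2, quoted above. Both of those compounds have lower numbers, and the spread among them is a 4.7-fold higher number from compound 1 to compound 2 (0.68 log units; beyond the scatter). A modest move toward a lower number, meaning higher toxicity in this test, therefore seems likely, though with real uncertainty. The expected step is a 2.8-fold lower number from compound 3 to compound 4 (0.45 log units; beyond the scatter). For compound 4 the estimated value is 45000 nM, with an expected range of 14000 nM to 130000 nM.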

Compound 4, half-maximal cytotoxic concentration: 200000 nM
For compound 4 the middle estimate is 4.4-fold (0.65 log units) below the measured one; the whole stated range lies below it.
By their numbers in this assay, from the lowest: compound 1; then compounds 2, 3 and 4 (each within the scatter of the next, the first and the last beyond it).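

In this assay the step of a 1.6-fold higher number from compound 3 to compound 4 (0.20 log units; within the scatter) shows no readable change, so on a nitrogen on an aromatic ring the open 3-hydroxy-1-methylpropyl chain, which has no ring, cannot be told apart from the ring-bearing (4-chloropyridin-3-yl)methyl group. The same chain does stand clear of the other two groups, with a 2.9-fold higher number from compound 2 to compound 4 (0.47 log units; beyond the scatter) as a modest step and a 14-fold higher number from compound 1 to compound 4 (1.14 log units; beyond the scatter) as a large one. Among these four compounds, then, a number at the top of the series does not depend on having a ring in this group.

The compounds shown leave open whether the hydroxyl counts for anything, which a 1-methylpropyl chain without it could test, and whether an amine or a carboxylic acid in its place would give a similar number. Nothing available here gives a reason for these differences.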